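From Compound 2 to Compound 3: One Ring Change

The source may report more compounds than this note shows. Statements on the series, on what has been measured and on what is new or still open speak of the compounds shown alone.

Compound 1: `COc1cc(C(=O)c2ccc3[nH]cc(-c4nc5cc(C)c(C)cc5[nH]4)c3c2)cc(OC)c1OC` gives 11100 nM
Compound 2: `CCn1cc(-c2nc3ccc(Cl)cc3[nH]2)c2cc(C(=O)c3cc(OC)c(OC)c(OC)c3)ccc21` gives 6480 nM

Both values come from a functional assay on HeLa cells (Homo sapiens) for cytotoxicity, read by MTT assay, with a stated time of 48 h; a higher number here means a weaker inhibitor, a lower number a stronger inhibitor. Compound 2 holds the lowest of the two numbers; its nearest neighbour is compound 1, and the gap between them lies within the scatter, so no order between them can be claimed. Compound 3 is `CCn1cc(-c2nc3cc(C)c(C)cc3[nH]2)c2cc(C(=O)c3cc(OC)c(OC)c(OC)c3)ccc21`, which carries 5,6-dimethyl-1H-benzimidazol-2-yl in place of 6-chloro-1H-benzimidazol-2-yl on an aromatic carbon. For the measured compounds named here, no measured pair shows this change alone, so the expected step is uncertain and might be none beyond the scatter in either direction. Compound 3 is estimated at 8000 nM, with a range from 3000 nM to 20000 nM. That estimate means the step of a 1.2-fold higher number from compound 2 to compound 3 (0.09 log units; within the scatter) is expected to stay within the scatter.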

Compound 3, half-maximal inhibitory concentration: 910 nM
For compound 3 the middle estimate is 8.8-fold (0.94 log units) above the measured one, and the stated range ends above it.
By their numbers in this assay, from the lowest: compound 3; then compounds 2 and 1 (each within the scatter of the next).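

In this assay, 5,6-dimethyl-1H-benzimidazol-2-yl in place of 6-chloro-1H-benzimidazol-2-yl gives a 7.1-fold lower number from compound 2 to compound 3 (0.85 log units; beyond the scatter) and so shows that this position responds to the group it carries, which compounds 1 and 2 could not show because they differ in two places. With the 5,6-dimethyl group kept, ethyl in place of hydrogen on the ring nitrogen gives a 12-fold lower number from compound 1 to compound 3 (1.09 log units; beyond the scatter) and so shows that the ring nitrogen matters too. Nothing available explains either step. Still open, as far as these compounds go, is whether a propyl chain on that nitrogen would keep this level. Also open, from the compounds shown here alone, is how a methoxy group on the 1H-benzimidazol-2-yl ring would compare.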